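From a pyrrole to a methylfuran on the shared core

The source may report more compounds than this note shows. Statements on the series, on what has been measured and on what is new or still open speak of the compounds shown alone.

Compound 2 `c1c[nH]c(-c2ccccc2OCC2=NCCN2)c1` carries a pyrrol-2-yl group on its core. In a functional assay for activation of Alpha-1B adrenergic receptor (Homo sapiens), read by calcium flux (a lower number here means that less compound is needed, a higher number that more compound is needed for the effect), compound 2 gives 1 nM, and among the numbers shown this is the only measured value. Compound 1 `Cc1cccnc1-c1ccccc1OCC1=NCCN1` reaches only a limit of the assay in this assay, where compound 1 gives < 100000 nM. The evidence about it is just (the limit of < 100000 nM in this assay, at which 1 of the 2 values shown sits), which does not tell how far compound 1 and compound 2 lie apart. Compound 3 `Cc1ccoc1-c1ccccc1OCC1=NCCN1` has not yet been measured; it differs from compound 2 in one place: 3-methylfuran-2-yl in place of 1H-pyrrol-2-yl on an aromatic carbon. For the measured compounds named here, no step between measured compounds guides this change, so the expectation rests on the change itself, which trades the hydrogen-bond donor for a hydrogen-bond acceptor and adds a methyl. The step is expected to be a 10-fold higher number from compound 2 to compound 3 (1.00 log units; beyond the scatter) in this assay, beyond the usual scatter. Compound 3 is expected to give 10 nM in this assay, with a range from 1 nM to 100 nM.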

Compound 3, half-maximal effective concentration: < 100000 nM
Compound 3 gave a limit, no number; the forecaster's own chance of this, stated with the estimate: 5%; the middle value is on the limit's open side.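

In this assay, for the compounds shown here, compound 3 gives < 100000 nM, which is a limit of the assay and not a number, so no step from compound 2 to compound 3 can be read. The compounds shown leave open how far compound 3 lies from compound 2, and whether the change of ring or the methyl of the 3-methylfuran-2-yl group counts for more.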